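Shrinking the Amide Substituent in a Bile Acid Receptor Series

The compounds below may be only part of what the source reports. "The series", "measured", "known", "first", "only" and "open" are said of these compounds alone.

Of the compounds shown here, two have been measured in an assay on isolated protein with Bile acid receptor (Homo sapiens) as the target; a higher number here means that more compound is needed for the effect, a lower number that less compound is needed. Compound 1 `COC(=O)/C=C/c1cccc(N(Cc2ccc(/C=C/c3c(Cl)cccc3Cl)cc2)C(=O)C(C)C)c1` gives 195 nM, and compound 2 `COC(=O)/C=C/c1cccc(N(Cc2ccc(-c3c(OC)cccc3OC)cc2)C(=O)C2CCCCC2)c1` gives 77 nM, the lower of the two numbers, with compound 1 standing higher and the gap lying beyond the scatter. Compound 3 `COC(=O)/C=C/c1cccc(N(Cc2ccc(-c3c(OC)cccc3OC)cc2)C(=O)C(C)C)c1` is not yet measured; it differs from compound 2 by isopropyl in place of cyclohexyl on a carbonyl carbon. For the measured compounds named here, no measured pair shows this change on its own, so its outcome is uncertain. The change is expected to cost a little potency, a 2.1-fold higher number from compound 2 to compound 3 (0.32 log units; beyond the scatter), a step somewhat beyond the scatter. Compound 3 is therefore estimated at 160 nM, within a range from 60 nM to 450 nM.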

Compound 3, half-maximal effective concentration: 95 nM
Beside the measured number, compound 3's estimate is 1.7-fold (0.23 log units) above it; low and high end bracket the measured number.
By their numbers in this assay, from the lowest: compounds 2 and 3 (each within the scatter of the next); then compound 1.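

Isopropyl in place of cyclohexyl on a carbonyl carbon gives a 1.2-fold higher number from compound 2 to compound 3 (0.09 log units; within the scatter), so with the 2,6-dimethoxyphenyl group present, this position does not need the six-membered ring. With isopropyl held constant, 2,6-dimethoxyphenyl in place of 2-(2,6-dichlorophenyl)ethenyl on an aromatic carbon gives a 2.1-fold lower number from compound 1 to compound 3 (0.31 log units; beyond the scatter), so the earlier gap between compound 1 and compound 2 follows this aromatic group rather than the carbonyl substituent. No supporting data explain either step. As far as these compounds go, whether methyl or an amine on the carbonyl carbon would behave like isopropyl remains open. So does whether cyclohexyl and isopropyl also match alongside 2-(2,6-dichlorophenyl)ethenyl.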